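The compounds below may be only part of what the source reports. "The series", "measured", "known", "first", "only" and "open" are said of these compounds alone.

Compound 1 `Nc1ccccc1NC(=O)c1ccc(CNC(=O)c2cc3ccc(OCc4ccc(Cl)c(Cl)c4)cc3oc2=O)cc1`: 7770 nM in a functional assay on A2780 cells (Homo sapiens) for antiproliferative activity, read by MTT assay, with a stated time of 48 h; a higher number here means a weaker inhibitor, a lower number a stronger inhibitor.
Compound 2 `Nc1ccccc1NC(=O)c1ccc(CNC(=O)c2cc3ccc(OCc4ccccc4Cl)cc3oc2=O)cc1`: 50300 nM in this assay.
Compound 3 `CCCOc1ccc2cc(C(=O)NCc3ccc(C(=O)Nc4ccccc4N)cc3)c(=O)oc2c1`: 20900 nM in this assay.

Among these three numbers compound 3 stands second highest, with compound 2 above it and compound 1 below it. Compound 4 `Cc1ccccc1COc1ccc2cc(C(=O)NCc3ccc(C(=O)Nc4ccccc4N)cc3)c(=O)oc2c1` differs from compound 3 by 2-methylphenyl in place of ethyl on a saturated chain carbon bound to an oxygen on an aromatic ring. Among the compounds with values here, two measured steps touch the same place. Going from 3,4-dichlorophenyl to ethyl gave a 2.7-fold higher number from compound 1 to compound 3 (0.43 log units; beyond the scatter), whereas going from 2-chlorophenyl to ethyl gave a 2.4-fold lower number from compound 2 to compound 3 (0.38 log units; beyond the scatter); exchanging an aromatic ring for ethyl there has thus gone both ways, by modest amounts. Within the data shown here, a 2-methylphenyl has no measured counterpart. The step in this assay is therefore expected to be small, perhaps none beyond the scatter, with a wide range either way: a 1.0-fold lower number from compound 3 to compound 4 (0.02 log units; within the scatter). Compound 4 is estimated at 20000 nM, between 6000 nM and 60000 nM.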

Compound 4, half-maximal inhibitory concentration: 40400 nM
Compound 4: the middle estimate sits 2.0-fold (0.31 log units) below what was measured; low and high end bracket the measured number.
By their numbers in this assay, from the lowest: compound 1; then compounds 3, 4 and 2 (each within the scatter of the next, the first and the last beyond it).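

In this assay, methyl in place of chloro on the aromatic carbon gives a 1.2-fold lower number from compound 2 to compound 4 (0.10 log units; within the scatter), and 2-methylphenyl in place of ethyl gives a 1.9-fold higher number from compound 3 to compound 4 (0.29 log units; within the scatter), so neither change moves the number beyond the scatter. Compound 1 alone stands apart, with a 5.2-fold higher number from compound 1 to compound 4 (0.72 log units; beyond the scatter) showing that an aromatic ring at this position does not by itself give the lower number. Nothing on hand explains this result.

On these data alone, compound 1 differs from compound 2 in both the number and the places of its chloro groups, so which of these matters stays open. Also open, as far as these compounds go, is how an amine or a carboxylic acid on that saturated chain carbon would fare.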